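The compounds below may be only part of what the source reports. "The series", "measured", "known", "first", "only" and "open" are said of these compounds alone.

Measured so far in an ADME assay on HeLa Rh cells (Homo sapiens) for cytotoxicity, read by microscopy; on this read-out lower numbers stand for higher toxicity in this test and higher numbers for lower toxicity in this test:
- Compound 1 `COc1cc(CC(O)c2ccc(-c3ccc([N+](=O)[O-])cc3)cc2)c([N+](=O)[O-])cc1OC` gives 21000 nM
- Compound 2 `COc1cc(CC(O)c2ccc(-c3ccc(F)cc3)cc2)c([N+](=O)[O-])cc1OC` gives 4500 nM
- Compound 3 `COc1cc(CC(O)c2ccc(-c3ccc(Cl)cc3)cc2)c([N+](=O)[O-])cc1OC` gives 4100 nM

Compound 3 stands level with compound 2 (a 1.1-fold lower number from compound 2 to compound 3 (0.04 log units; within the scatter)) at the low end of these numbers, and clearly under compound 1 (a 5.1-fold lower number from compound 1 to compound 3 (0.71 log units; beyond the scatter)). Compound 4 `COc1cc(CC(O)c2ccc(-c3cccc(Cl)c3)cc2)c([N+](=O)[O-])cc1OC` has the same atoms joined differently (3-chlorophenyl in place of 4-chlorophenyl on an aromatic carbon), with 3-chlorophenyl in place of 4-chlorophenyl on an aromatic carbon. Among the compounds with values here, no measured pair shows this kind of shift. The closest evidence is chloro in place of fluoro (a 1.1-fold lower number from compound 2 to compound 3 (0.04 log units; within the scatter)), whereas replacing nitro with fluoro (a 4.7-fold lower number from compound 1 to compound 2 (0.67 log units; beyond the scatter)) is a different kind of change. No step beyond the scatter is therefore expected (a 1.1-fold higher number from compound 3 to compound 4 (0.04 log units; within the scatter)). For compound 4 the estimated value is 4500 nM (expected range 2000 nM to 10000 nM).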

Compound 4, half-maximal cytotoxic concentration: 5900 nM
Compound 4: middle estimate off by 1.3-fold (0.12 log units), on the low side; low and high end bracket the measured number.
By their numbers in this assay, from the lowest: compounds 3, 2 and 4 (each within the scatter of the next); then compound 1.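

In this assay, moving the chlorine from 4-chlorophenyl to 3-chlorophenyl changes nothing beyond the scatter (a 1.4-fold higher number from compound 3 to compound 4 (0.16 log units; within the scatter)), so on this read-out the shift of chlorine around the ring matters little. Compound 4 also stays level with the fluoro compound (a 1.3-fold higher number from compound 2 to compound 4 (0.12 log units; within the scatter)), while the gap from the nitro compound remains beyond the scatter (a 3.6-fold lower number from compound 1 to compound 4 (0.55 log units; beyond the scatter)). No measurement shown explains these numbers. Still open, on these data alone, is what an amine or a carboxylic acid would do in place of the chlorine on this ring.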